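Trifluoromethyl for chloro on a chalcone-like scaffold

This account rests on a few compounds, and the source may have more. Where it says the series, first, only, none or still open, it means among the compounds named here.

Measured compounds:
Compound 1 `COc1cc(O)c(CC=C(C)C)c(O)c1C(=O)/C=C/c1ccc(C(F)(F)F)cc1`: 6500 nM
Compound 2 `COc1cc(O)cc(O)c1C(=O)/C=C/c1ccc(C)cc1`: > 50000 nM
Compound 3 `COc1cc(O)cc(O)c1C(=O)/C=C/c1ccc(Cl)cc1`: 12200 nM

Three compounds sharing one core were tested in a functional assay on HepG2 cells (Homo sapiens) for inhibition, read by MTT assay, with a stated time of 72 h; on this read-out higher numbers stand for weaker inhibition and lower numbers for stronger inhibition. Compound 2 gives > 50000 nM, which is the limit of > 50000 nM in this assay, at which 1 of the 3 values shown sits, rather than a number. Compound 3 gives 12200 nM, and compound 1, which carries an extra prenyl group on the core, gives 6500 nM; these two numbers lie within the scatter of each other, so neither can be called the stronger.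

The step of an at least 4.0-fold lower number from compound 2 to compound 3 (0.61 log units; beyond the scatter) is the only measured one. It shows that swapping the group on that aromatic carbon can move the number by a modest amount.

Compound 4 `COc1cc(O)cc(O)c1C(=O)/C=C/c1ccc(C(F)(F)F)cc1` is not yet measured. It differs from compound 3 by trifluoromethyl in place of chloro on an aromatic carbon. Compound 1 already carries a trifluoromethyl at that place and sits close to compound 3, so the change is expected to stay within or just beyond the scatter, and any shift is expected to be a 1.4-fold lower number from compound 3 to compound 4 (0.13 log units; within the scatter). Compound 4 is therefore expected at 9000 nM, between 3000 nM and 30000 nM.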

Compound 4, half-maximal inhibitory concentration: 14100 nM
The estimate for compound 4 lay 1.6-fold (0.19 log units) below the measured number, and the stated range covers the measured number.
By their numbers in this assay, from the lowest: compounds 1, 3 and 4 (each within the scatter of the next, the first and the last beyond it). At a limit, above all of these: compound 2.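

In this assay, the step of a 1.2-fold higher number from compound 3 to compound 4 (0.06 log units; within the scatter) lies within the scatter, so on this aromatic carbon, para to a large group, trifluoromethyl and chloro cannot be told apart, even though trifluoromethyl brings 4 heavy atoms where chloro brings 1. Methyl stands apart from both, with an at least 3.5-fold lower number from compound 2 to compound 4 (0.54 log units; beyond the scatter), but this step has no fixed size, as compound 2 sits at a limit and not at a number: the limit of > 50000 nM in this assay, at which 1 of the 4 values shown sits. With trifluoromethyl held fixed, hydrogen in place of 3-methylbut-2-en-1-yl on an aromatic carbon now gives a step of its own, a 2.2-fold higher number from compound 1 to compound 4 (0.34 log units; beyond the scatter), which no earlier pair could show.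

Going by these compounds, whether an amine or a nitrile at the first place would behave like chloro and trifluoromethyl remains open. So does whether a longer chain in place of 3-methylbut-2-en-1-yl would shift the number further.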